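Diaryl triazole sulfones: ether variation and microsomal clearance

A few compounds are considered here, and "the series" means these few. Any claim that something is new, unique, unknown or untested is made for them only; others in the source may bear on it.

Among the measured compounds shown here, compound 1 `CC(C)COc1ncc(-c2cc(F)c(-c3nnc(S(=O)(=O)CC4CC4)[nH]3)cc2F)cc1Cl` gives 58 uL/min in an ADME assay on microsomes from liver (Rattus norvegicus) for metabolic stability (a lower number here means slower removal, a higher number faster removal of the compound), the lower of the two numbers so far. Compound 2 `COc1cc(-c2nnc(S(=O)(=O)C3CCC3)[nH]2)ccc1-c1cnc(OCC(C)C)c(Cl)c1` gives 61 uL/min in this assay, which lies within the scatter of compound 1, so the two are not distinguished. Compound 3 `O=S(=O)(CC1CC1)c1nnc(-c2cc(F)c(-c3cnc(Oc4ccc(F)cc4F)c(Cl)c3)cc2F)[nH]1` is not yet measured in this assay. It differs from compound 1 in one place: 2,4-difluorophenyl in place of isobutyl on an oxygen on an aromatic ring. For the measured compounds named here, no measured step of this kind is available. For compound 3 the expectation is a step of a 1.2-fold lower number from compound 1 to compound 3 (0.08 log units; within the scatter), with no clear direction beyond the scatter. Compound 3 is thus estimated at 48 uL/min in this assay, in a range from 22 uL/min to 105 uL/min.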

Compound 3, intrinsic clearance in a liver preparation (reported as CLH), per the amount of preparation that the assay uses: 22 uL/min
Compound 3: the middle estimate sits 2.2-fold (0.34 log units) above what was measured, and the stated range covers the measured number.
By their numbers in this assay, from the lowest: compound 3; then compounds 1 and 2 (each within the scatter of the next).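

Among the compounds shown here, at the oxygen on the aromatic ring, 2,4-difluorophenyl in place of isobutyl gives a 2.6-fold lower number from compound 1 to compound 3 (0.42 log units; beyond the scatter) in this assay, the first step beyond the scatter. For the compounds shown here, the earlier values gave no step, so this is the first sign that the group on this oxygen can shift clearance. No evidence in hand accounts for the step.

Open, as far as these compounds go, is whether the ring or its fluorines carry the step: an unsubstituted phenyl or a cyclohexyl on the same oxygen would separate the two. From the compounds shown here alone, whether the change holds on the core of compound 2 also stays open.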